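A few compounds are considered here, and "the series" means these few. Any claim that something is new, unique, unknown or untested is made for them only; others in the source may bear on it.

Measured compounds:
Compound 1 `CCCCCCCCCCC[C@@H](C[C@@H]1OC(=O)[C@H]1CCCCCC)OC(=O)[C@H](C)NC=O` — in an assay on membranes from brain for inhibition of Fatty-acid amide hydrolase 1 (Rattus norvegicus) (on this read-out higher numbers stand for weaker inhibition and lower numbers for stronger inhibition), compound 1 gives only a limit, > 50000 nM.
Compound 2 `CCCCCCCCCCC[C@@H](C[C@@H]1OC(=O)[C@H]1CCCCCC)OC(=O)CCNC=O` — in this assay compound 2 gives only a limit, > 50000 nM.
Compound 3 `CCCCCCCCCCC[C@@H](C[C@@H]1OC(=O)[C@H]1CCCCCC)OC(=O)[C@@H](NC(C)=O)C(C)C` — in this assay compound 3 gives only a limit, > 50000 nM.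

Compound 3 thus stands at the limit in this assay, and so do the other two, as shown by the limit of > 50000 nM in this assay, at which 3 of the 3 values shown sit. None of the steps among them can be read: a step that the two limits leave unreadable from compound 1 to compound 2, a step that the two limits leave unreadable from compound 1 to compound 3 and a step that the two limits leave unreadable from compound 2 to compound 3 all stay hidden behind the same limit. Compound 4 `CCCCCCCCCCC[C@@H](C[C@@H]1OC(=O)[C@H]1CCCCCC)OC(=O)[C@@H]1CCCN1C=O` differs from compound 3 by 1-formylpyrrolidin-2-yl in place of 1-acetamido-2-methylpropyl on a carbonyl carbon. Since the three measured steps give no readable size, no change beyond the scatter is expected from this step, a number no higher from compound 3 to compound 4 (the limit leaves the size open). Compound 4 is therefore expected to give 50000 nM in this assay, with a range from 20000 nM to 50000 nM.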

Compound 4, half-maximal inhibitory concentration: 3400 nM
For compound 4 the middle estimate is 15-fold (1.17 log units) above the measured one, and the stated range ends above it.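

In this assay the group on this carbonyl carbon turns out to matter, with 1-formylpyrrolidin-2-yl giving an at least 14-fold lower number from compound 3 to compound 4 (1.16 log units; beyond the scatter), an at least 14-fold lower number from compound 2 to compound 4 (1.16 log units; beyond the scatter) and an at least 14-fold lower number from compound 1 to compound 4 (1.16 log units; beyond the scatter). The steps among compound 1, compound 2 and compound 3 cannot be read, and only compound 4 comes off the limit: the limit of > 50000 nM in this assay, at which 3 of the 4 values shown sit.

Of the four groups, only 1-formylpyrrolidin-2-yl carries a ring. From the compounds shown here alone, whether the step belongs to the ring or to the formyl on its nitrogen stays open, as does what an acetyl on that nitrogen, a six-membered ring or a free amine would give.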